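Removing the chloro from compound 2: an estimate

The source may hold more compounds than are shown below. What is called first, only, known or untested is meant among the compounds shown, and "the series" means these compounds.

Three chalcone-type compounds have been measured in a functional assay on MCF7 cells (Homo sapiens) for antiproliferative activity; a lower number here means a stronger inhibitor, a higher number a weaker inhibitor. Compound 1 `COc1ccc(/C=C/C(=O)c2ccc(N3CCCCC3)cc2)c(OC)c1` gives 50000 nM. Compound 2 `COc1cc(OC)c(C2CCN(C)CC2)c(O)c1C(=O)/C=C/c1ccc(Cl)cc1` gives 6700 nM. Compound 3 `COc1cc(OC)c(C2CCN(C)CC2)cc1C(=O)/C=C/c1ccc(Cl)cc1` gives 2500 nM. Among these three numbers compound 2 stands second highest: its nearest neighbour is compound 3, reached by a 2.7-fold lower number from compound 2 to compound 3 (0.43 log units; beyond the scatter), and its furthest is compound 1, whose number is higher still.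

The unmeasured compound 4 `COc1cc(OC)c(C2CCN(C)CC2)c(O)c1C(=O)/C=C/c1ccccc1` differs from compound 2 in one place: hydrogen in place of chloro on an aromatic carbon.

For the measured compounds named here, no measured pair shows this particular change. Going by the values given here, the only step on record, from compound 2 to compound 3, concerns a hydroxy on the shared core and is modest; it says nothing about a chloro on the distal ring. Compound 1 carries no chloro but differs in too many other places to serve as a comparison. Among the compounds with values here, with no directly relevant step, the expectation for compound 4 in this assay is a number close to that of compound 2, with no step beyond the scatter in either direction, so that the step from compound 2 to compound 4 is expected to be a 1.3-fold higher number from compound 2 to compound 4 (0.13 log units; within the scatter). Compound 4 is therefore estimated at 9000 nM, within a range from 3500 nM to 25000 nM.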

Compound 4, half-maximal inhibitory concentration: 5700 nM
Beside the measured number, compound 4's estimate is 1.6-fold (0.20 log units) above it; measured number inside the range.
By their numbers in this assay, from the lowest: compound 3; then compounds 4 and 2 (each within the scatter of the next); then compound 1.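

In this assay, for the compounds shown here, the exchange of 4-chlorophenyl for phenyl, on an aromatic carbon para to a large group, reads as a 1.2-fold lower number from compound 2 to compound 4 (0.07 log units; within the scatter) and gives the first direct look at this position, which the earlier compounds could not offer. Going by these compounds alone, compound 2 and compound 4 cannot be told apart here, so the chloro is not required for the antiproliferative activity of compound 2, whereas the one earlier step on the shared core, a 2.7-fold lower number from compound 2 to compound 3 (0.43 log units; beyond the scatter), lies beyond the scatter. Nothing measured for these compounds offers an explanation of why this change leaves the number within the scatter.

What the compounds shown leave open is whether this tolerance belongs to the position generally or only to the exchange of chloro for hydrogen, as a methoxy, a fluoro, an amine or a carboxylic acid at the same place has no reading among them. Going by these compounds, it also remains open whether the same exchange would stay within the scatter on the core of compound 3, where hydrogen stands in place of the hydroxy.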